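This account rests on a few compounds, and the source may have more. Where it says the series, first, only, none or still open, it means among the compounds named here.

Measured so far in a functional assay on ACHN cells (Homo sapiens) for inhibition, read by sulforhodamine B assay, with a stated time of 48 h; on this read-out lower numbers stand for stronger inhibition of growth and higher numbers for weaker inhibition of growth:
compound 1 `COc1ccc(-c2[nH]c3ccccc3c2/C=C(\C#N)S(=O)(=O)c2ccccc2)cc1`: 1900 nM
compound 2 `COc1ccc(-c2[nH]c3ccc(OC)cc3c2/C=C(\C#N)S(=O)(=O)c2ccccc2)cc1`: 1800 nM

Compound 2 gives the lowest of these two numbers in this assay, yet compound 1 sits within the scatter of it, the step being a 1.1-fold lower number from compound 1 to compound 2 (0.02 log units; within the scatter). Compound 3 `COc1ccc2[nH]c(-c3ccccc3)c(/C=C(\C#N)S(=O)(=O)c3ccccc3)c2c1` differs from compound 2 by hydrogen in place of methoxy on an aromatic carbon. For the measured compounds named here, the single measured step concerns a methoxy at a different place and stayed within the scatter; no measured step tests the methoxy para to the large group. Compound 3 is therefore expected to show a 1.1-fold higher number from compound 2 to compound 3 (0.05 log units; within the scatter), nothing beyond the scatter. The estimated value of compound 3 is 2000 nM, with a range from 900 nM to 4500 nM.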

Compound 3, concentration for 50% growth inhibition: 12900 nM
The estimate for compound 3 lay 6.5-fold (0.81 log units) below the measured number; the measured number lies above the stated range.
By their numbers in this assay, from the lowest: compounds 2 and 1 (each within the scatter of the next); then compound 3.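

Replacing 4-methoxyphenyl with phenyl gives a 7.2-fold higher number from compound 2 to compound 3 (0.86 log units; beyond the scatter) in this assay and so, unlike the earlier methoxy step, goes beyond the scatter. The methoxy para to a large group therefore counts for growth inhibition in this pair, whereas the methoxy tested earlier did not change the number beyond the scatter. Nothing available here accounts for this difference. On these data alone, it remains open whether a hydroxy group, an amine or a fluorine atom at this place would keep the lower number of compound 2. As far as these compounds go, whether a longer alkoxy chain would do the same also stays open.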